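Iodo for Hydroxy on the Five-Membered Ring of Compound 3

The source may hold more compounds than are shown below. What is called first, only, known or untested is meant among the compounds shown, and "the series" means these compounds.

Compound 1, `COc1nc2c(N)ncnc2n1Cc1ccccc1`, in a functional assay (spleen, spleen) for activation, with Mus musculus as the target (a higher number here means that more compound is needed for the effect, a lower number that less compound is needed), gives > 10 uM, a limit of the assay.
Compound 2, `CSc1nc2c(N)ncnc2n1Cc1ccccc1`, in this assay gives > 10 uM, also a limit.
Compound 3, `Nc1ncnc2c1nc(O)n2Cc1ccccc1`, in this assay gives 10 uM.

Within the data shown here, compound 3 holds the only number among the three results; the other two sit at the limit of > 10 uM in this assay, at which 2 of the 3 values shown sit. The step from compound 1 to compound 2 is a step that the two limits leave unreadable from compound 1 to compound 2. The two remaining steps are a number no higher from compound 1 to compound 3 (the limit leaves the size open) and a number no higher from compound 2 to compound 3 (the limit leaves the size open), so neither tells how far compound 3 lies from its neighbours.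

Compound 4, `Nc1ncnc2c1nc(I)n2Cc1ccccc1`, differs from compound 3 as follows: iodo in place of hydroxy on an aromatic carbon. Among the measured compounds shown here, no measured step replaces the hydroxy with a halogen, so nothing here reads on the size of this change. The two limits show only that a methoxy or methylsulfanyl at that place gives no number at all. The step from compound 3 to compound 4 is therefore expected to be a 1.5-fold higher number from compound 3 to compound 4 (0.18 log units; within the scatter), most likely ending at a limit. Compound 4 is estimated in this assay at 15 uM, between 5 uM and 50 uM.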

Compound 4, minimum effective concentration: > 10 uM
Compound 4: only a limit was reported; the forecaster's own chance of this, stated with the estimate: 60%; the middle value lies beyond the limit too.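

Iodo in place of hydroxy, on this aromatic carbon between two ring nitrogen atoms, gives a number no lower from compound 3 to compound 4 (the limit leaves the size open), the first reading of a halogen at this place. In this assay, among these compounds, compound 4 gives > 10 uM, a limit of the assay, so iodo joins methoxy and methylsulfanyl in yielding no number and hydroxy remains the only group here that has one. The steps linking compound 1 and compound 2 to compound 4 cannot be read, and the results now gather at one limit: the limit of > 10 uM in this assay, at which 3 of the 4 values shown sit.

On these data alone, how far compound 4 actually lies from compound 3 stays open, since only a direction is available. As far as these compounds go, whether an amine or a carboxylic acid on this carbon would give a number at all, and whether any group here would need less compound than hydroxy, also remains open.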